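From 3-Methylbenzyl to 4-Methoxybenzyl: An Expected Outcome

This account rests on a few compounds, and the source may have more. Where it says the series, first, only, none or still open, it means among the compounds named here.

compound 1, `COc1cccc(OC)c1OCCNCCOc1ccccc1OCc1ccccc1C`: 11500 nM
compound 2, `COc1cccc(OC)c1OCCNCCOc1ccccc1OCc1cccc(C)c1`: 12000 nM
compound 3, `COc1cccc(OC)c1OCCNCCOc1ccccc1OCc1ccccc1[N+](=O)[O-]`: 13200 nM

Of the compounds shown here, three sharing one core have been tested in a functional assay on PC-3 cells (Homo sapiens) for cytotoxicity, read by sulforhodamine B assay; a lower number here means a stronger inhibitor of growth, a higher number a weaker inhibitor of growth. They differ only in the group bound to the saturated chain carbon on the aryl ether. Compound 2 stands second highest of the three numbers. Its nearest neighbour is compound 1, and the step of a 1.0-fold higher number from compound 1 to compound 2 (0.02 log units; within the scatter) does not leave the scatter. Towards compound 3 the step of a 1.1-fold higher number from compound 2 to compound 3 (0.04 log units; within the scatter) is likewise within the scatter, as is the step of a 1.1-fold higher number from compound 1 to compound 3 (0.06 log units; within the scatter) between the other two. Across these three, then, the change at this position has produced nothing that can be distinguished from repeat measurement.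

Compound 4, `COc1ccc(COc2ccccc2OCCNCCOc2c(OC)cccc2OC)cc1`, has not yet been measured. Against compound 2 it shows (4-methoxyphenyl in place of 3-methylphenyl on a saturated chain carbon bound to an oxygen on an aromatic ring). Within the data shown here, the steps that bear on it are those at the same place, from compound 1 to compound 2 and from compound 2 to compound 3, both of which were flat. Nothing in these three compounds suggests the new group would behave otherwise, so compound 4 is expected to give a step of no change at the digits printed from compound 2 to compound 4 (within the scatter) in this assay, none beyond the scatter. The estimate for compound 4 is therefore 12000 nM, with a range from 6000 nM to 25000 nM.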

Compound 4, concentration for 50% growth inhibition: 8500 nM
Compound 4: the middle estimate sits 1.4-fold (0.15 log units) above what was measured; the measured number falls inside the stated range.
By their numbers in this assay, from the lowest: compounds 4, 1, 2 and 3 (each within the scatter of the next).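

In this assay, the step to the new group is a 1.4-fold lower number from compound 2 to compound 4 (0.15 log units; within the scatter), and the comparisons with the other two compounds read a 1.4-fold lower number from compound 1 to compound 4 (0.13 log units; within the scatter) and a 1.6-fold lower number from compound 3 to compound 4 (0.19 log units; within the scatter), so each of the three stays within the scatter. The earlier compounds had shown this flatness only for 2-methylphenyl, 3-methylphenyl and 2-nitrophenyl; compound 4 extends it to 4-methoxyphenyl, whose methoxy oxygen brings one more heavy atom and one hydrogen-bond acceptor than 3-methylphenyl without producing a step that can be told from repeat measurement. No measurement is at hand that explains why these four numbers sit so closely together.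

The compounds shown leave open whether any group at this place can move the number beyond the scatter, for example a phenyl ring carrying a carboxylic acid or a dimethylamino group, or a longer chain in place of the benzyl group. They also leave open whether a saturated ring such as cyclohexyl, in place of the aromatic ring, would stay as flat as the four aromatic groups have.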